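The source may hold more compounds than are shown below. What is called first, only, known or untested is meant among the compounds shown, and "the series" means these compounds.

Working notes on the series. In an ADME assay on MT4 cells (Homo sapiens) for cytotoxicity, read by MTT assay (a lower number here means that less compound is tolerated, a higher number that more compound is tolerated), compound 1 `CCc1c(Cc2cc(C)cc(C)c2)nc(SCc2ccc(OC)cc2)[nH]c1=O` gives > 317000 nM, which is a limit of the assay rather than a number. In this assay compound 2 `CCc1c(Cc2cc(C)cc(C)c2)nc(SCc2ccc([N+](=O)[O-])cc2)[nH]c1=O` gives > 305000 nM, likewise a limit of the assay. The change from compound 1 to compound 2, nitro in place of methoxy on an aromatic carbon, yields a step that the two limits leave unreadable from compound 1 to compound 2 that the two limits leave unreadable. Compound 2 therefore stands only at a limit, sitting at the limit of > 305000 nM in this assay, at which 1 of the 2 values shown sits. Among the measured compounds shown here, the one other value shown is also a limit, sitting at the limit of > 317000 nM in this assay, at which 1 of the 2 values shown sits.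

Compound 3 `CCc1c(Cc2cc(C)cc(C)c2)nc(SCc2ccccc2)[nH]c1=O` differs from compound 2 by hydrogen in place of nitro on an aromatic carbon. For the measured compounds named here, no measured step gives a readable size for a change of this kind, so no step beyond the scatter is expected in this assay in either direction. Compound 3 is therefore expected to give about 300000 nM, within a range from 100000 nM to 600000 nM. The estimated step of an at least 1.0-fold lower number from compound 2 to compound 3 (0.00 log units; that floor lies within the scatter) is thus expected to be none beyond the scatter, most likely again reported only as a limit.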

Compound 3, half-maximal cytotoxic concentration: > 343000 nM
Compound 3 ended at the assay's limit; the forecaster's own chance of this, stated with the estimate: 75%; middle value at least 1.1-fold (0.05 log units) away from the limit.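

In this assay compound 3 gives > 343000 nM, a limit of the assay and not a number. Among the compounds shown here, compound 1, compound 2 and compound 3 all stand at limits, so no step among them can be read. The compounds shown leave open where any true half-maximal cytotoxic concentration lies, and whether methoxy, nitro or hydrogen on that aromatic carbon makes any difference to it.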